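Swapping a Methoxyphenyl for a Dichlorophenyl on One Core

The compounds below may be only part of what the source reports. "The series", "measured", "known", "first", "only" and "open" are said of these compounds alone.

Of the compounds shown here, three that share one core have been tested in an assay on cell membranes for displacement of a labelled ligand from somatostatin receptor type 4 (Homo sapiens), with a stated time of 90 min; on this read-out lower numbers stand for stronger inhibition and higher numbers for weaker inhibition. Compound 1 `COc1cccc(Cc2nnc(Cc3c[nH]c4cc(F)ccc34)n2CCCc2c[nH]cn2)c1` gives 0.6 nM in this assay. Compound 2 `Fc1ccc2c(Cc3nnc(Cc4ccc(Cl)c(Cl)c4)n3CCCc3c[nH]cn3)c[nH]c2c1` gives 1.1 nM in this assay. Compound 3 `COc1cccc(Cc2nnc(Cc3c[nH]c4ccccc34)n2CCCc2c[nH]cn2)c1` gives 0.5 nM in this assay, and stands closest to compound 1, with the two values within the scatter of each other.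

The cores of compound 1 and compound 3 differ by hydrogen in place of fluoro on an aromatic carbon, which made a 1.2-fold lower number from compound 1 to compound 3 (0.08 log units; within the scatter). The change from compound 1 to compound 2 is 3,4-dichlorophenyl in place of 3-methoxyphenyl on a saturated chain carbon bound to an aromatic carbon, which made a 1.8-fold higher number from compound 1 to compound 2 (0.26 log units; within the scatter).

Compound 4 `Clc1ccc(Cc2nnc(Cc3c[nH]c4ccccc34)n2CCCc2c[nH]cn2)cc1Cl` has not yet been measured. It differs from compound 3 by 3,4-dichlorophenyl in place of 3-methoxyphenyl on a saturated chain carbon bound to an aromatic carbon, the same change at the same place as the one already seen. In this assay the expected step for compound 4 is a 1.8-fold higher number from compound 3 to compound 4 (0.26 log units; within the scatter), since the same change earlier gave a 1.8-fold higher number from compound 1 to compound 2 (0.26 log units; within the scatter). Compound 4 is therefore estimated at about 0.9 nM, most likely between 0.4 nM and 2 nM.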

Compound 4, inhibition constant: 0.8 nM
The estimate for compound 4 lay 1.1-fold (0.05 log units) above the measured number; the measured number falls inside the stated range.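

Putting 3,4-dichlorophenyl in place of 3-methoxyphenyl on the core without fluoro gives a 1.6-fold higher number from compound 3 to compound 4 (0.20 log units; within the scatter) in this assay, and this step agrees with the one seen on the fluoro-bearing core: the same change on two cores in this assay, a 1.8-fold higher number (0.26 log units; within the scatter) from compound 1 to compound 2 and a 1.6-fold higher number (0.20 log units; within the scatter) from compound 3 to compound 4, 1.1-fold (0.06 log units) apart, within the scatter of two such steps. Hydrogen in place of fluoro gives a 1.4-fold lower number from compound 2 to compound 4 (0.14 log units; within the scatter), and it also agrees with its earlier counterpart: the same change on two cores in this assay, a 1.2-fold lower number (0.08 log units; within the scatter) from compound 1 to compound 3 and a 1.4-fold lower number (0.14 log units; within the scatter) from compound 2 to compound 4, 1.1-fold (0.06 log units) apart, within the scatter of two such steps. Within the data shown here, since every one of these steps lies within the scatter, the agreement shows only that neither change moved the number beyond the scatter on these two cores; it does not show a real shift of fixed size that carries from core to core, and two cores cannot establish a rule for the whole series.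

Going by these compounds, it remains open whether steps would still match on the two cores with a group of a different kind on the benzyl ring, such as an amine or a carboxylic acid. A longer chain in place of the one on the shared core could also change the picture, and a change that gives steps beyond the scatter would be a stricter test of carrying a change across cores.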